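Replacing a carboxypyrrolidinylmethyl arm with formyl on a stilbene scaffold

A few compounds are considered here, and "the series" means these few. Any claim that something is new, unique, unknown or untested is made for them only; others in the source may bear on it.

Three close relatives of one stilbene core have been tested in an ADME assay on HEK293 cells (Homo sapiens) for cytotoxicity, read by CCK-8 assay, with a stated time of 48 h; a lower number here means a stronger inhibitor, a higher number a weaker inhibitor. Compound 1 `COc1ccc(/C=C\c2cc(OC)c(OC)c(OC)c2)cc1OCc1ccc(CN2CC[C@H](C(=O)O)C2)cc1` carries a (3-carboxypyrrolidin-1-yl)methyl group on its benzyl ether ring. In this assay compound 1 gives > 50000 nM, which is a limit of the assay and not a number. Compound 2 `COc1ccc(/C=C\c2cc(OC)c(OC)c(OC)c2)cc1OCc1ccc(CN2CCCCC2C(=O)O)cc1` gives > 50000 nM, again only a limit. Compound 3 `COc1ccc(/C=C\c2cc(OC)c(OC)c(OC)c2)cc1OCc1ccc(CN2CC[C@H](O)C2)cc1` gives > 50000 nM, likewise a limit. Consequently the step that the two limits leave unreadable from compound 1 to compound 2 cannot be read, nor can a step that the two limits leave unreadable from compound 1 to compound 3 or a step that the two limits leave unreadable from compound 2 to compound 3: all three compounds sit at the limit of > 50000 nM in this assay, at which 3 of the 3 values shown sit, so compound 1 stands level with its two companions as far as the numbers can tell.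

Compound 4 `COc1ccc(/C=C\c2cc(OC)c(OC)c(OC)c2)cc1OCc1ccc(C=O)cc1` differs from compound 1 as follows: formyl in place of (3-carboxypyrrolidin-1-yl)methyl on an aromatic carbon. Within the data shown here, no measured step bears on this particular change, since every recorded step involves only the amine-bearing groups and each of them is hidden by the limits. With no readable step to anchor it, the expectation for compound 4 rests on the fact that all three measured relatives remain at the limit. The step from compound 1 to compound 4 is therefore expected to be modest, an at least 1.2-fold lower number from compound 1 to compound 4 (0.09 log units; that floor lies within the scatter), with a real chance that compound 4 also returns only a limit. For compound 4 the estimated value in this assay is 40000 nM, between 5000 nM and 200000 nM.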

Compound 4, half-maximal inhibitory concentration: 46000 nM
Compound 4: the middle estimate sits 1.2-fold (0.06 log units) below what was measured; measured number inside the range.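

In this assay, among these compounds, compound 4 gives 46000 nM, the only reading in this set that is a number and not a limit, so formyl on this aromatic carbon, para to a large group, gives a value that can be placed on the scale. Set against the three saturated ring-bearing arms, the change reads as an at least 1.0-fold lower number from compound 1 to compound 4 (0.03 log units; that floor lies within the scatter), as an at least 1.0-fold lower number from compound 3 to compound 4 (0.03 log units; that floor lies within the scatter) and as an at least 1.0-fold lower number from compound 2 to compound 4 (0.03 log units; that floor lies within the scatter); each of these is only a floor, so none of them establishes a real drop. The steps among compound 1, compound 2 and compound 3 still cannot be read, and those three stay together at one limit: the limit of > 50000 nM in this assay, at which 3 of the 4 values shown sit.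

The compounds shown leave open how far above compound 4 the three limited compounds really lie, and so whether removing the arm changes the number at all. A simple amine, a carboxylic acid or a hydroxymethyl group on this same aromatic carbon, without the saturated ring, would show whether the value of compound 4 belongs to formyl itself or merely to the absence of the larger arm.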